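Swapping an Octyl Chain for a Fluorophenyl Ring

The compounds below may be only part of what the source reports. "The series", "measured", "known", "first", "only" and "open" are said of these compounds alone.

Compound 1 `CCCCCCCCc1c(-c2ccccc2)sc(C(C)C)c1/C=C/[C@@H](O)C[C@@H](O)CC(=O)O`: > 10000 nM
Compound 2 `CC(C)c1sc(-c2ccccc2)c(-c2ccccc2F)c1/C=C/[C@@H](O)C[C@@H](O)CC(=O)O`: 233 nM
Compound 3 `CC(C)c1sc(-c2ccccc2)c(-c2cccc(F)c2)c1/C=C/[C@@H](O)C[C@@H](O)CC(=O)O`: 49 nM

All three were tested in an assay on microsomes for inhibition of 3-hydroxy-3-methylglutaryl-coenzyme A reductase (Rattus norvegicus); a lower number here means a stronger inhibitor, a higher number a weaker inhibitor. For compound 1 this assay reports only a limit, (the limit of > 10000 nM in this assay, at which 1 of the 3 values shown sits), so its true value is not known as a number. Compound 2 and compound 3, which carry a fluorophenyl group where compound 1 carries the octyl chain, both give measured numbers. Compound 4 `CC(C)c1sc(-c2ccccc2)c(-c2ccc(F)cc2)c1/C=C/[C@@H](O)C[C@@H](O)CC(=O)O` has not yet been measured; it differs from compound 1 in this way: 4-fluorophenyl in place of octyl on an aromatic carbon. Within the data shown here, two measured steps bear directly on this change: an at least 42-fold lower number from compound 1 to compound 2 (1.63 log units; beyond the scatter) and an at least 200-fold lower number from compound 1 to compound 3 (2.30 log units; beyond the scatter). Between the two fluorophenyl variants, a 4.8-fold lower number from compound 2 to compound 3 (0.68 log units; beyond the scatter). Both steps from compound 1 are large and point the same way, so a large drop in this assay is expected for compound 4 as well. The expected step for compound 4 is an at least 100-fold lower number from compound 1 to compound 4 (2.00 log units; beyond the scatter). Compound 4 is therefore estimated at 100 nM, with a likely range from 20 nM to 500 nM.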

Compound 4, half-maximal inhibitory concentration: 4.4 nM
For compound 4 the middle estimate is 23-fold (1.36 log units) above the measured one; measured number below the stated range.
By their numbers in this assay, from the lowest: compound 4; then compound 3; then compound 2. At a limit, above all of these: compound 1.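

Among these compounds, the place of a single fluorine on this ring turns out to matter far more than the earlier compounds suggested: they showed only a modest gap between the 2-fluorophenyl and 3-fluorophenyl groups, whereas in this assay the 4-fluorophenyl group gives an 11-fold lower number from compound 3 to compound 4 (1.05 log units; beyond the scatter) and a 53-fold lower number from compound 2 to compound 4 (1.72 log units; beyond the scatter). The full replacement of octyl now reaches an at least 2200-fold lower number from compound 1 to compound 4 (3.35 log units; beyond the scatter), so compound 4 is the strongest inhibitor of the four. That step has a floor but no known size, as compound 1 gives only a limit, not a number: the limit of > 10000 nM in this assay, at which 1 of the 4 values shown sits.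

Going by these compounds, how a plain phenyl, a 4-chlorophenyl or a 4-methoxyphenyl group would compare at this position remains open. So does the effect of a shorter chain such as ethyl in place of octyl.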